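The source may hold more compounds than are shown below. What is called first, only, known or untested is meant among the compounds shown, and "the series" means these compounds.

Measured compounds in a functional assay on cells (Splenocyte, Mus musculus, strain BALB/c) for inhibition, read by scintillation counting and thymidine incorporation, with a stated time of 72 h; on this read-out lower numbers stand for stronger inhibition and higher numbers for weaker inhibition:

Compound 1, `CC(/C=N/Nc1ccc([N+](=O)[O-])cc1)=N\NC(=O)c1ccccc1`. In this assay compound 1 gives > 12000 nM, a limit of the assay rather than a number.
Compound 2, `CC(/C=N/Nc1ccc([N+](=O)[O-])cc1)=N\NC(=O)c1ccc(N)cc1`. In this assay compound 2 gives > 12000 nM, again only a limit.
Compound 3, `CC(/C=N/Nc1ccc([N+](=O)[O-])cc1)=N\NC(=O)c1cccc(C)c1`. In this assay compound 3 gives > 12000 nM, once more a limit.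

Compound 3 thus stands at the limit of this assay, as do the other two, so no order among them can be read (the limit of > 12000 nM in this assay, at which 3 of the 3 values shown sit). The steps from compound 1 to compound 2 (a step that the two limits leave unreadable from compound 1 to compound 2), from compound 1 to compound 3 (a step that the two limits leave unreadable from compound 1 to compound 3) and from compound 2 to compound 3 (a step that the two limits leave unreadable from compound 2 to compound 3) are all unreadable in size.

Compound 4 is `COc1cc(C(=O)N/N=C(C)/C=N/Nc2ccc([N+](=O)[O-])cc2)ccc1O`. It differs from compound 3 by 4-hydroxy-3-methoxyphenyl in place of 3-methylphenyl on a carbonyl carbon. None of the measured steps bears on this change in a readable way, so no direction beyond the scatter can be expected from them; the series so far has shown nothing but limits. The estimate for compound 4 in this assay is therefore 15000 nM, expected between 5000 nM and 50000 nM, a step that the limit leaves unreadable from compound 3 to compound 4 that is expected to stay at or near the limit.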

Compound 4, half-maximal inhibitory concentration: 5100 nM
Estimate against measurement, compound 4: 2.9-fold (0.47 log units) above, and the stated range covers the measured number.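

In this assay, the place on the carbonyl carbon proves able to move the read-out: 4-hydroxy-3-methoxyphenyl gives an at least 2.3-fold lower number from compound 3 to compound 4 (0.37 log units; beyond the scatter) against 3-methylphenyl, an at least 2.3-fold lower number from compound 2 to compound 4 (0.37 log units; beyond the scatter) against 4-aminophenyl and an at least 2.3-fold lower number from compound 1 to compound 4 (0.37 log units; beyond the scatter) against phenyl. As far as these compounds go, each of these steps has a limit at one end, so its full size stays open. Compound 4 is the only compound shown that comes off the limit, and the steps among compound 1, compound 2 and compound 3 cannot be read: the limit of > 12000 nM in this assay, at which 3 of the 4 values shown sit.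

From the compounds shown here alone, the change brings in hydroxy and methoxy together, so it remains open whether either alone would carry the step. Also open, going by these compounds, is whether a carboxylic acid or a longer alkoxy chain on the same aromatic ring would give a lower number still.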